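Swapping the Benzyl Ether Substituent on the Weakest Compound

The compounds below may be only part of what the source reports. "The series", "measured", "known", "first", "only" and "open" are said of these compounds alone.

Compound 1 `Cc1cccc(COc2ccc(-c3cc(CN4CCN(Cc5ccc(C(F)(F)F)cc5)CC4)no3)cc2)c1` is measured in a functional assay on Huh-7 cells (Homo sapiens) for antiproliferative activity, read by sulforhodamine B assay, with a stated time of 72 h (a higher number here means a weaker inhibitor, a lower number a stronger inhibitor), where compound 1 gives 5000 nM, the highest of the three numbers available. Compound 2 `FC(F)(F)c1ccc(CN2CCN(Cc3cc(-c4ccc(OCc5cccc(Cl)c5)cc4)on3)CC2)cc1` gives 200 nM, and compound 3 `Fc1cccc(COc2ccc(-c3cc(CN4CCN(Cc5ccc(C(F)(F)F)cc5)CC4)no3)cc2)c1` gives 1300 nM. Both measured steps away from compound 1 lower the number: a 25-fold lower number from compound 1 to compound 2 (1.40 log units; beyond the scatter) and a 3.8-fold lower number from compound 1 to compound 3 (0.59 log units; beyond the scatter). Compound 4 `COc1ccccc1COc1ccc(-c2cc(CN3CCN(Cc4ccc(C(F)(F)F)cc4)CC3)no2)cc1` differs from compound 1 by 2-methoxyphenyl in place of 3-methylphenyl on a saturated chain carbon bound to an oxygen on an aromatic ring. Neither measured step involves a methoxy group; each replaces the methyl with a halogen, so they bear on this change only loosely. Their shared direction makes a lowering plausible, while its size remains uncertain. Compound 4 is expected to give about 2500 nM, within 700 nM to 9000 nM. That estimate means a step of a 2.0-fold lower number from compound 1 to compound 4 (0.30 log units; within the scatter) is expected.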

Compound 4, half-maximal inhibitory concentration: 900 nM
Beside the measured number, compound 4's estimate is 2.8-fold (0.44 log units) above it, and the stated range covers the measured number.
By their numbers in this assay, from the lowest: compound 2; then compounds 4 and 3 (each within the scatter of the next); then compound 1.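

The fall in number from the methyl compound does not depend on a halogen: 2-methoxyphenyl in place of 3-methylphenyl gives a 5.6-fold lower number from compound 1 to compound 4 (0.74 log units; beyond the scatter) in this assay. Against the halogen compounds, this group gives a 1.4-fold lower number from compound 3 to compound 4 (0.16 log units; within the scatter), so it cannot be told apart from 3-fluorophenyl, while 3-chlorophenyl stays ahead, with a 4.5-fold higher number from compound 2 to compound 4 (0.65 log units; beyond the scatter). No measurement at hand explains these differences.

This change alters both the group and its place on the ring, and the compounds shown cannot separate the two. A 3-methoxyphenyl group would test the place, and a 3-aminophenyl group would test whether an amine is tolerated here.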